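This account rests on a few compounds, and the source may have more. Where it says the series, first, only, none or still open, it means among the compounds named here.

Measured so far in an in vitro ADME assay on microsomes from liver (Homo sapiens) for pharmacokinetics, read by LC-MS, with a stated time of 10 min, tested at 1 uM; a higher number here means faster removal of the compound, a lower number slower removal:

compound 1 `CN1C[C@H](C(=O)Nc2ccc(F)cc2)[C@@H](c2ccc(/C=C/C(=O)Nc3ccccc3N)cc2)C1`: 5 mL/min/kg
compound 2 `Cc1cc(NC(=O)[C@H]2CN(C)C[C@@H]2c2ccc(/C=C/C(=O)Nc3ccccc3N)cc2)ccc1F`: 15 mL/min/kg

Going by the values given here, compound 1 stands lowest of the two numbers; its nearest neighbour is compound 2, the only other measured member of the series. Among the compounds with values here, the one measured step, a 3.0-fold higher number from compound 1 to compound 2 (0.48 log units; beyond the scatter), concerns a methyl in place of hydrogen on an aromatic carbon and does not touch the amide-type nitrogen altered here.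

Compound 3 `CN1C[C@H](C(=O)Nc2ccc(Cl)cn2)[C@@H](c2ccc(/C=C/C(=O)Nc3ccccc3N)cc2)C1` is not yet measured. It differs from compound 1 by 5-chloropyridin-2-yl in place of 4-fluorophenyl on an amide-type nitrogen. Within the data shown here, no measured step bears on this change, so there is nothing to set a direction. The expectation is a step from compound 1 to compound 3 of a 1.2-fold higher number from compound 1 to compound 3 (0.08 log units; within the scatter), that is, no change beyond the scatter. Compound 3 is therefore estimated at 6 mL/min/kg, with a range from 2.5 mL/min/kg to 15 mL/min/kg, the range left wide to allow for an upward move like that seen toward compound 2.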

Compound 3, clearance: 13 mL/min/kg
Compound 3: middle estimate off by 2.2-fold (0.34 log units), on the low side; the measured number falls inside the stated range.
By their numbers in this assay, from the lowest: compound 1; then compounds 3 and 2 (each within the scatter of the next).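

In this assay the aryl group on the amide-type nitrogen matters: 5-chloropyridin-2-yl in place of 4-fluorophenyl gives a 2.6-fold higher number from compound 1 to compound 3 (0.41 log units; beyond the scatter) and leaves compound 1 lowest of the three, with its steps to both others beyond the scatter. The assay does not separate 5-chloropyridin-2-yl from 4-fluoro-3-methylphenyl at this position, with a 1.2-fold lower number from compound 2 to compound 3 (0.06 log units; within the scatter) as the printed step. No measurement at hand gives a reason for the rise from compound 1.

Open, as far as these compounds go, is whether that rise follows the ring nitrogen or the chlorine, which enter together; 4-chlorophenyl or 5-fluoropyridin-2-yl on the same nitrogen would separate them. Also open, from the compounds shown here alone, is how a non-aromatic group such as cyclohexyl would read at this position.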